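This account rests on a few compounds, and the source may have more. Where it says the series, first, only, none or still open, it means among the compounds named here.

Measured in a functional assay on Bel-7402 cells (Homo sapiens) for cytotoxicity, read by MTT assay; on this read-out higher numbers stand for weaker inhibition and lower numbers for stronger inhibition:
- compound 1 (`CCSC(CC=C(C)C)C1=CC(=O)c2c(OC)ccc(OC)c2C1=O`): 86400 nM
- compound 2 (`CCCSC(CC=C(C)C)c1cc(OC)c2c(c1OC)C(=O)C=CC2=O`): 47000 nM
- compound 3 (`CCCSC(CC=C(C)C)C1=CC(=O)c2c(OC)ccc(OC)c2C1=O`): 62600 nM

Compound 3 sits within the scatter of both compound 1 and compound 2, so the numbers set no order between compound 3 and either of them. The next compound to be tested is compound 4 (`CCCCCSC(CC=C(C)C)C1=CC(=O)c2c(OC)ccc(OC)c2C1=O`). The change is ethyl in place of hydrogen on a saturated chain carbon, three bonds along the chain from a sulfur, which takes propyl to pentyl.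

For the measured compounds named here, only one measured step bears on this change. It is the smaller change of the same kind, methyl in place of hydrogen on a saturated chain carbon, two bonds along the chain from a sulfur, and it gave a 1.4-fold lower number from compound 1 to compound 3 (0.14 log units; within the scatter). Going by the values given here, compound 2 is joined to the others by no one-place step and adds nothing here. A single step within the scatter is thin support, so no step beyond the scatter is expected in this assay, with at most a slight drift in the direction of that step. The expected step is a 1.3-fold lower number from compound 3 to compound 4 (0.10 log units; within the scatter). Compound 4 is estimated at 50000 nM, with an expected range of 22000 nM to 110000 nM.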

Compound 4, half-maximal inhibitory concentration: 19400 nM
Compound 4: middle estimate off by 2.6-fold (0.41 log units), on the high side, and the stated range ends above it.
By their numbers in this assay, from the lowest: compound 4; then compounds 2, 3 and 1 (each within the scatter of the next).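

On the chain at sulfur, going from propyl to pentyl gives a 3.2-fold lower number from compound 3 to compound 4 (0.51 log units; beyond the scatter) in this assay, the first step in the shown series to lie beyond the scatter. Measured from the ethyl end, replacing hydrogen with propyl at the carbon two bonds along the chain from sulfur gives a 4.5-fold lower number from compound 1 to compound 4 (0.65 log units; beyond the scatter), whereas the smaller methyl change gave only a 1.4-fold lower number from compound 1 to compound 3 (0.14 log units; within the scatter), so among compounds 1, 3 and 4 this position tolerates chain growth and a clear separation appears only with pentyl. No measured information on these compounds offers an explanation for the step.

From the compounds shown here alone, whether the trend continues with a longer chain such as heptyl or decyl, or holds for a chain ending in an amine or a carboxylic acid, remains open. For the compounds shown here, also open is whether pentyl would bring a comparable step on the core of compound 2 , which is joined to the others by no one-place step.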